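Swapping Propargyl for Allyl on a Weak Transporter Scaffold

The source may report more compounds than this note shows. Statements on the series, on what has been measured and on what is new or still open speak of the compounds shown alone.

Compound 1 `C#CCN(CC=C)C(=O)[C@@]1(c2ccsc2)C[C@H]1CN` was tested in an assay on HEK293 cells for inhibition of sodium-dependent dopamine transporter (Homo sapiens) (on this read-out higher numbers stand for weaker inhibition and lower numbers for stronger inhibition), and returns only a limit there, > 10000 nM. Compound 2 `CCN(CC)C(=O)[C@@]1(c2cccnc2)C[C@H]1CN` likewise gives only a limit in this assay, > 10000 nM. Both readings sit at the limit of > 10000 nM in this assay, at which 2 of the 2 values shown sit, so compound 1 stands at the edge of what the data show, without a number of its own. Compound 3 `C=CCN(CC=C)C(=O)[C@@]1(c2ccsc2)C[C@H]1CN` carries the change (vinyl in place of ethynyl on a saturated chain carbon bound to an amide-type nitrogen), vinyl in place of ethynyl on a saturated chain carbon bound to an amide-type nitrogen. Among the measured compounds shown here, no measured step of this kind exists here, so no shift beyond the scatter is expected, and the estimated step is a step that the limit leaves unreadable from compound 1 to compound 3. Compound 3 is therefore expected near 15000 nM, within 4000 nM to 60000 nM.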

Compound 3, half-maximal inhibitory concentration: 8300 nM
For compound 3 the middle estimate is 1.8-fold (0.26 log units) above the measured one, and the stated range covers the measured number.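

With allyl in place of propargyl, compound 3 gives 8300 nM in this assay, so this change yields a number of its own at this position. The change reads as an at least 1.2-fold lower number from compound 1 to compound 3 (0.08 log units; that floor lies within the scatter), which fixes only a floor and leaves the true size of the step unknown. The other readings remain limits: the limit of > 10000 nM in this assay, at which 2 of the 3 values shown sit.

As far as these compounds go, whether a propyl chain or a benzyl group in place of the allyl would shift the number further remains open.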